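Isopentyl for 1-Methylbutyl: A Near-Neutral Swap Expected

The compounds below may be only part of what the source reports. "The series", "measured", "known", "first", "only" and "open" are said of these compounds alone.

Of the compounds shown here, three sharing one core have been tested in a functional assay (Oryctolagus cuniculus) for inhibition of platelet-activating factor receptor (Cavia porcellus); a higher number here means a weaker inhibitor, a lower number a stronger inhibitor. Compound 1 `CCCCCCCCCC(=O)OCC1CN(C(=O)c2cc(OC)c(OC)c(OC)c2)CCN1C(=O)c1cc(OC)c(OC)c(OC)c1`, which carries a nonyl chain on its carbonyl carbon, gives 2820 nM in this assay. Compound 2 `COc1cc(C(=O)N2CCN(C(=O)c3cc(OC)c(OC)c(OC)c3)C(COC(=O)NC(C)(C)C)C2)cc(OC)c1OC` gives 130 nM, and compound 3 `CCCC(C)NC(=O)OCC1CN(C(=O)c2cc(OC)c(OC)c(OC)c2)CCN1C(=O)c1cc(OC)c(OC)c(OC)c1` gives 100 nM. Compound 3 has the lowest number of the three: its nearest neighbour is compound 2, within the scatter, and its furthest is compound 1, well beyond it. The two large steps were a 22-fold lower number from compound 1 to compound 2 (1.34 log units; beyond the scatter) and a 28-fold lower number from compound 1 to compound 3 (1.45 log units; beyond the scatter), both arising when an amino group replaced the nonyl chain on the carbonyl carbon.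

Compound 4 `COc1cc(C(=O)N2CCN(C(=O)c3cc(OC)c(OC)c(OC)c3)C(COC(=O)NCCC(C)C)C2)cc(OC)c1OC` differs from compound 3 only in one place: isopentyl in place of 1-methylbutyl on an amide-type nitrogen. The measured step that bears most directly on this is a 1.3-fold lower number from compound 2 to compound 3 (0.11 log units; within the scatter), where one branched alkyl group on that same nitrogen replaced another and the number barely moved. By that precedent the rearrangement of the same atoms within the alkyl group on the amide-type nitrogen is expected to yield a 1.1-fold higher number from compound 3 to compound 4 (0.04 log units; within the scatter), a step of no meaningful size in either direction. Compound 4 is therefore estimated to give 110 nM in this assay, with a plausible range from 50 nM to 250 nM.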

Compound 4, half-maximal inhibitory concentration: 140 nM
Compound 4: middle estimate off by 1.3-fold (0.10 log units), on the low side, and the stated range covers the measured number.
By their numbers in this assay, from the lowest: compounds 3, 2 and 4 (each within the scatter of the next); then compound 1.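

With the same five carbons joined differently, isopentyl in place of 1-methylbutyl gives a 1.4-fold higher number from compound 3 to compound 4 (0.15 log units; within the scatter), and set against tert-butyl it gives a 1.1-fold higher number from compound 2 to compound 4 (0.03 log units; within the scatter), so in this assay three different alkyl groups on this amide-type nitrogen now stand within the scatter of one another. The replacement of nonyl on the carbonyl carbon also remains large with this third group, at a 20-fold lower number from compound 1 to compound 4 (1.30 log units; beyond the scatter), which shows that the large step seen earlier from compound 1 is not confined to the two alkyl groups tested before. Nothing shown here offers an explanation for why these alkyl groups sit so close together or why the step from compound 1 is so large.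

The compounds shown leave open whether this tolerance extends to a straight n-pentyl chain, a longer chain such as octyl, or a ring-bearing group such as cyclohexyl or benzyl on the same nitrogen. They also cannot separate the effect of the amino group from that of the alkyl group in the steps from compound 1, and a nonylamino group on the carbonyl carbon would bear directly on that question.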